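Replacing vinyl on the carbonyl carbon of compound 2

This account rests on a few compounds, and the source may have more. Where it says the series, first, only, none or still open, it means among the compounds named here.

In a functional assay on A549 cells (Homo sapiens) for antiproliferative activity, read by MTT assay, with a stated time of 72 h (on this read-out higher numbers stand for weaker inhibition and lower numbers for stronger inhibition), two compounds have been measured so far. Compound 1 (`CC(C)=CC(=O)Nc1cccc(Oc2nc(Nc3ccn(C)n3)nc3c2CSCC3)c1`) gives 44200 nM and compound 2 (`C=CC(=O)Nc1cccc(Oc2nc(Nc3ccc(OC)cc3)nc3c2CSCC3)c1`) gives 4220 nM. Compound 2 therefore holds the lower of the two numbers, and the gap lies beyond the usual scatter. The two compounds differ in more than one place, so the gap cannot be assigned to any single change.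

Compound 3 (`COc1ccc(Nc2nc3c(c(Oc4cccc(NC(=O)C=C(C)C)c4)n2)CSCC3)cc1`) departs from compound 2 in one place: 2-methylprop-1-en-1-yl in place of vinyl on a carbonyl carbon. In words, 2-methylprop-1-en-1-yl stands in place of vinyl on a carbonyl carbon. Among the measured compounds shown here, no measured pair isolates this change. For the measured compounds named here, the only indirect evidence is compound 1, which carries the same 2-methylprop-1-en-1-yl on a carbonyl carbon and gives 44200 nM in this assay. That evidence is weak, yet it points toward weaker inhibition. The expected shift is a 2.6-fold higher number from compound 2 to compound 3 (0.42 log units; beyond the scatter), in the direction of a higher number, and it may prove only modest. For compound 3 the estimated value is 11000 nM, with an expected range from 4000 nM to 32000 nM.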

Compound 3, half-maximal inhibitory concentration: 26900 nM
Compound 3: the middle estimate sits 2.4-fold (0.39 log units) below what was measured; low and high end bracket the measured number.
By their numbers in this assay, from the lowest: compound 2; then compounds 3 and 1 (each within the scatter of the next).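

In this assay, the change on the carbonyl carbon whose other neighbour is the amide-type nitrogen can now be read on its own: 2-methylprop-1-en-1-yl in place of vinyl gives a 6.4-fold higher number from compound 2 to compound 3 (0.80 log units; beyond the scatter) and so goes with weaker inhibition, with the rest of the molecule held constant. With 2-methylprop-1-en-1-yl on that carbonyl carbon, 4-methoxyphenyl in place of 1-methyl-1H-pyrazol-3-yl on a nitrogen on an aromatic ring gives a 1.6-fold lower number from compound 1 to compound 3 (0.22 log units; within the scatter) and so does not separate the two compounds. Of the two places in which compound 1 and compound 2 differ, only the change on the carbonyl carbon therefore shows a step beyond the scatter, although each step has been read in a single setting.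

No measurement at hand bears on the reason for the step on the carbonyl carbon. Still open, as far as these compounds go, is how this position responds to a single methyl on the vinyl group, a saturated ethyl group or a dimethylaminomethyl group on the vinyl, and whether the exchange on the nitrogen stays as silent with vinyl on the carbonyl carbon.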